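From Methyl to 4-Chlorophenyl on a Weakly Active Core

The source may report more compounds than this note shows. Statements on the series, on what has been measured and on what is new or still open speak of the compounds shown alone.

Compound 1 `Cc1noc(-c2cc3ccccc3[nH]2)n1` gives 30500 nM in a functional assay on MIA PaCa-2 cells (Homo sapiens) for antiproliferative activity, read by WST assay, with a stated time of 72 h (a lower number here means a stronger inhibitor, a higher number a weaker inhibitor), a weak result. Compound 2 `COc1ccc2[nH]c(-c3nc(C)no3)cc2c1` carries a methoxy in place of hydrogen on an aromatic carbon of the shared core. In this assay compound 2 reaches only the limit of the assay, > 50000 nM, and no number. The step of an at least 1.6-fold higher number from compound 1 to compound 2 (0.21 log units; that floor lies within the scatter) is therefore only a floor, and compound 2 stands at the limit of > 50000 nM in this assay, at which 1 of the 2 values shown sits.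

Compound 3 `COc1ccc2[nH]c(-c3nc(-c4ccc(Cl)cc4)no3)cc2c1` differs from compound 2 by 4-chlorophenyl in place of methyl on an aromatic carbon. No measured step in this set bears on that change: the one step shown alters a different group on the core. Compound 2 thus offers only a floor to build on, and the expectation for compound 3 rests on the structural change alone. The estimate for compound 3 is 20000 nM, within 3000 nM to 50000 nM. The expected step, an at least 2.5-fold lower number from compound 2 to compound 3 (0.39 log units; beyond the scatter), carries wide uncertainty.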

Compound 3, half-maximal inhibitory concentration: 22700 nM
For compound 3 the middle estimate is 1.1-fold (0.05 log units) below the measured one; the range from low to high includes it.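

Compound 3 shows that the aromatic carbon between two ring nitrogen atoms responds to change: in this assay, 4-chlorophenyl in place of methyl gives an at least 2.2-fold lower number from compound 2 to compound 3 (0.34 log units; beyond the scatter). Among these compounds, this is the first step in the set that is printed as beyond the scatter, and it brings the methoxy-bearing core back to a measurable value. Its true size remains unknown because compound 2 stands only at a limit of the assay: the limit of > 50000 nM in this assay, at which 1 of the 3 values shown sits.

The compounds shown leave open whether the change at this place depends on the chlorine or on the six-membered aromatic ring, which a plain phenyl would separate. Also open, going by these compounds, are how 4-chlorophenyl behaves on the core of compound 1, without the methoxy, and whether an amine or a carboxylic acid at this place would shift the number further.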